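A few compounds are considered here, and "the series" means these few. Any claim that something is new, unique, unknown or untested is made for them only; others in the source may bear on it.

Working notes on a set of urea compounds tested in a functional assay (aorta) with Rattus norvegicus as the target; on this read-out higher numbers stand for an effect only at larger amounts of compound and lower numbers for an effect already at smaller amounts.

Compound 1 `CC1(C)CC(NC(=O)Nc2ccccc2)c2cc(F)ccc2O1` carries fluoro on the fused ring and an unsubstituted phenyl urea; in this assay compound 1 gives 17100 nM. Compound 2 `CC1(C)CC(NC(=O)Nc2ccccc2)c2cc(Cl)ccc2O1` differs by chloro in place of fluoro on an aromatic carbon, and in this assay compound 2 gives 7800 nM, a step of a 2.2-fold lower number from compound 1 to compound 2 (0.34 log units; beyond the scatter). Compound 3 `Cc1ccccc1NC(=O)NC1CC(C)(C)Oc2ccc(F)cc21` keeps the fluoro core of compound 1 and differs from it by methyl in place of hydrogen on an aromatic carbon. In this assay compound 3 gives > 30000 nM, which is a limit of the assay and not a number. The step of an at least 1.7-fold higher number from compound 1 to compound 3 (0.24 log units; that floor lies within the scatter) is therefore only a floor, set by the limit of > 30000 nM in this assay, at which 1 of the 3 values shown sits.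

Compound 4 `Cc1ccccc1NC(=O)NC1CC(C)(C)Oc2ccc(Cl)cc21` has not yet been measured in this assay. Among the measured compounds shown here, it differs from compound 3 by chloro in place of fluoro on an aromatic carbon; this is the same change as the one made from compound 1 to compound 2, and it occurs twice among the compounds here. The cores of compound 3 and compound 4 differ from those of compound 1 and compound 2 by methyl in place of hydrogen on an aromatic carbon.

The expected step of an at least 1.5-fold lower number from compound 3 to compound 4 (0.17 log units; that floor lies within the scatter) is modelled on the measured step of a 2.2-fold lower number from compound 1 to compound 2 (0.34 log units; beyond the scatter), since compound 3 starts from a limit rather than a number, the starting point is itself uncertain. For compound 4 the expected value in this assay is 20000 nM, estimated to lie between 8000 nM and 60000 nM, with a real chance that only a limit is reported again.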

Compound 4, half-maximal effective concentration: > 10000 nM
Compound 4 was reported as a limit; the forecaster's own chance of this, stated with the estimate: 40%; the middle value is on the limit's open side.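

Methyl in place of hydrogen on an aromatic carbon of the chloro core gives an at least 1.2-fold higher number from compound 2 to compound 4 (0.10 log units; that floor lies within the scatter), and this step is only a floor, set by a limit: the limit of > 10000 nM in this assay, at which 1 of the 4 values shown sits.

The same change on the fluoro core is also only a floor, so both steps leave the size of the change unsettled, and neither floor lies beyond the scatter: the same change on two cores in this assay, an at least 1.7-fold higher number (0.24 log units; that floor lies within the scatter) from compound 1 to compound 3 and an at least 1.2-fold higher number (0.10 log units; that floor lies within the scatter) from compound 2 to compound 4; the limit leaves it open whether they differ

The series therefore shows that neither methyl compound gave a measured number in this assay, but it does not show that the change carries from one core to the other with a given size, or that it raises the number at all; the step from compound 3 to compound 4 cannot be read, as both of its ends are limits.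

Left open is how far compound 3 and compound 4 lie past their limits, and whether chloro in place of fluoro has on the methyl compounds the effect seen in a 2.2-fold lower number from compound 1 to compound 2 (0.34 log units; beyond the scatter). Also open, on these data alone, is how this assay would read for a methoxy group or a nitrile on the phenyl of the urea, or for an amine on the fused ring.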